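Swapping the anilide aryl group on a bis-benzylidene piperidinone core

This account rests on a few compounds, and the source may have more. Where it says the series, first, only, none or still open, it means among the compounds named here.

Compound 1 `Cc1cccc(C)c1NC(=O)/C=C/C(=O)N1C/C(=C\c2ccc([N+](=O)[O-])cc2)C(=O)/C(=C/c2ccc([N+](=O)[O-])cc2)C1` gives the lowest of the three numbers in a functional assay on Molt4/C8 cells (Homo sapiens) for cytotoxicity (a lower number here means a stronger inhibitor, a higher number a weaker inhibitor), with compound 1 at 210 nM. Compound 2 `Cc1ccc(NC(=O)/C=C/C(=O)N2C/C(=C\c3ccccc3)C(=O)/C(=C/c3ccccc3)C2)cc1` gives 660 nM, and compound 3 `CC(=O)c1ccc(NC(=O)/C=C/C(=O)N2C/C(=C\c3ccccc3)C(=O)/C(=C/c3ccccc3)C2)cc1` gives 1400 nM. Among the compounds with values here, the one measured step that alters the amide aryl substituent, a 2.1-fold higher number from compound 2 to compound 3 (0.33 log units; beyond the scatter), was modest. Compound 4 `O=C(/C=C/C(=O)N1C/C(=C\c2ccc([N+](=O)[O-])cc2)C(=O)/C(=C/c2ccc([N+](=O)[O-])cc2)C1)Nc1ccc(Cl)c(Cl)c1` differs from compound 1 only at the amide-type nitrogen (3,4-dichlorophenyl in place of 2,6-dimethylphenyl on an amide-type nitrogen). Within the data shown here, no measured pair changes the anilide ring in this way, so only a modest shift, most likely toward a higher number, is expected. Compound 4 is therefore estimated at 320 nM in this assay, within 110 nM to 950 nM, which means an expected step of a 1.5-fold higher number from compound 1 to compound 4 (0.18 log units; within the scatter).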

Compound 4, half-maximal inhibitory concentration: 600 nM
Compound 4: middle estimate off by 1.9-fold (0.27 log units), on the low side; the measured number falls inside the stated range.
By their numbers in this assay, from the lowest: compound 1; then compounds 4 and 2 (each within the scatter of the next); then compound 3.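

In this assay, replacing 2,6-dimethylphenyl with 3,4-dichlorophenyl on the amide-type nitrogen gives a 2.9-fold higher number from compound 1 to compound 4 (0.46 log units; beyond the scatter) and so shows that the number responds to a change of the whole aryl group while the rest of compound 1 stays fixed. The change keeps a single six-membered aromatic ring of carbon only, so the shift comes with a swap of its substituents, not of the ring itself. Going by these compounds, it remains open whether the move from methyl to chlorine or their placement on the ring governs this step, and whether an amine or a carboxylic acid on that ring would keep the number near that of compound 1. No evidence is available to explain the step.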